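The source may report more compounds than this note shows. Statements on the series, on what has been measured and on what is new or still open speak of the compounds shown alone.

Measured so far in an ADME assay for permeability, using PAMPA, at pH 7.4; a higher number here means that the compound crosses the layer faster, a lower number that the compound crosses the layer more slowly:
- compound 1 `Cc1cc(NC(=O)Nc2ccc(C(C)(C)C)cc2)c2ccccc2n1` gives 142 10^-6 cm/s
- compound 2 `COC(=O)c1ccc(NC(=O)Nc2cc(C)nc3ccccc23)cc1` gives 448 10^-6 cm/s
- compound 3 `Cc1cc(NC(=O)Nc2cccnc2)c2ccccc2n1` gives 63 10^-6 cm/s

Compound 3 gives the lowest of the three numbers, and its gaps to compound 1 and to compound 2 both lie beyond the scatter. Next in line is compound 4 `Cc1cc(NC(=O)Nc2ccc(Cl)cc2)c2ccccc2n1`, which has 4-chlorophenyl in place of pyridin-3-yl on an amide-type nitrogen.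

Going by the values given here, the only measured step between compounds differing in one place is a 3.2-fold higher number from compound 1 to compound 2 (0.50 log units; beyond the scatter), a modest change with methoxycarbonyl in place of tert-butyl on an aromatic carbon. It does not involve pyridin-3-yl, so it bears on the new change only indirectly, as a guide to how far this assay can move with one group exchanged. Neither compound 1 nor compound 2 carries pyridin-3-yl, and both stand above compound 3 in the values. With so few compounds, this is thin support, but it points to a rise of similar modest size rather than no change.

The expected step is a 3.2-fold higher number from compound 3 to compound 4 (0.50 log units; beyond the scatter). For compound 4 the estimated value is 200 10^-6 cm/s, with an expected range from 90 10^-6 cm/s to 450 10^-6 cm/s.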

Compound 4, apparent permeability: 537 10^-6 cm/s
For compound 4 the middle estimate is 2.7-fold (0.43 log units) below the measured one; measured number outside the range, above it.
By their numbers in this assay, from the lowest: compound 3; then compound 1; then compounds 2 and 4 (each within the scatter of the next).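

In this assay, going by these compounds alone, 4-chlorophenyl in place of pyridin-3-yl on an amide-type nitrogen gives an 8.5-fold higher number from compound 3 to compound 4 (0.93 log units; beyond the scatter), the first direct reading of this exchange, and it shows that replacing the one-nitrogen aromatic ring with a carbon-only aromatic ring bearing chloro can shift the number beyond the scatter. The aromatic carbon that carries the varied group now also has three members to compare: chloro in place of methoxycarbonyl gives a 1.2-fold higher number from compound 2 to compound 4 (0.08 log units; within the scatter), so these two groups cannot be told apart here, while chloro in place of tert-butyl gives a 3.8-fold higher number from compound 1 to compound 4 (0.58 log units; beyond the scatter), which sets the tert-butyl compound apart from the other two. The data shown offer no measured basis for explaining any of these steps.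

A plain phenyl on the same amide-type nitrogen would show how much of the step from pyridin-3-yl belongs to the ring nitrogen and how much to the chloro. Also open, on these data alone, is how the number responds to an amine or a carboxylic acid on that aromatic carbon, and whether the order among chloro, methoxycarbonyl and tert-butyl holds with another group on the shared core.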